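Cytotoxicity of a sulfonyl series: the next compound

This account rests on a few compounds, and the source may have more. Where it says the series, first, only, none or still open, it means among the compounds named here.

compound 1 `Cc1ccc(S(=O)(=O)c2nc3ccccc3nc2Nc2ccccc2)cc1`: 19000 nM
compound 2 `COc1ccc(Nc2nc3ccccc3nc2S(=O)(=O)c2ccc(C)cc2)cc1`: "not determined" (no result reported)
compound 3 `COc1cc(Nc2nc3ccccc3nc2S(=O)(=O)c2ccc(C)cc2)cc(OC)c1`: "not determined" (no result reported)

The series has been examined in a functional assay on KB cells (Homo sapiens) for cytotoxicity, read by MTT assay, with a stated time of 72 h (on this read-out lower numbers stand for stronger inhibition and higher numbers for weaker inhibition), and so far it offers a single number. In this assay compound 1 gives 19000 nM. The record for compound 2 reads "not determined" (no result reported), so it offers no result to compare. Compound 3 stands in the same position: its entry is "not determined" (no result reported), and it cannot be placed above or below any other compound on the numbers available.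

The next compound to be tested is compound 4 `Cc1ccc(S(=O)(=O)c2nc3ccccc3nc2Nc2ccc(F)cc2)cc1`. The structural change is this: 4-fluorophenyl in place of 3,5-dimethoxyphenyl on a nitrogen on an aromatic ring. In words, a 4-fluorophenyl stands in place of 3,5-dimethoxyphenyl on a nitrogen on an aromatic ring.

Among the measured compounds shown here, with no number at the starting end, the data cannot measure this change directly, and no step between measured compounds is available as a guide. For the measured compounds named here, the only anchor is compound 1 at 19000 nM. The expectation is therefore for a result within the scatter of that value, with no step in either direction in this assay. Compound 4 is estimated at 15000 nM, with an expected range from 5000 nM to 45000 nM.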

Compound 4, half-maximal inhibitory concentration: 8950 nM
Compound 4: middle estimate off by 1.7-fold (0.22 log units), on the high side; the range from low to high includes it.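

In this assay the series now has its first measured step: placing fluoro in place of hydrogen on an aromatic carbon of the group on the nitrogen gives a 2.1-fold lower number from compound 1 to compound 4 (0.33 log units; beyond the scatter) and so a modest change that lies beyond the usual scatter. This shows that the aromatic ring on that nitrogen is a place where one small replacement can move the number, which compound 1 alone could not show, and the direction here is towards stronger inhibition. Nothing available explains why the fluoro substituent has this effect.

The steps that start from compound 2 or compound 3, including the exchange of 3,5-dimethoxyphenyl for 4-fluorophenyl, cannot be read, so the compounds shown say nothing about how the methoxy-bearing rings compare with either measured compound. They also leave open whether a chlorine, a methyl group or an amine in place of the fluoro would move the number in the same direction or further, and whether the step would hold with a different group on the sulfonyl.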